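From Trimethoxyphenyl to Dihydroxyphenyl in a Cytotoxicity Series

This account rests on a few compounds, and the source may have more. Where it says the series, first, only, none or still open, it means among the compounds named here.

In a functional assay on PC-3 cells (Homo sapiens) for cytotoxicity, read by MTT assay, with a stated time of 72 h (on this read-out higher numbers stand for weaker inhibition and lower numbers for stronger inhibition), compound 1 `COc1cc2ncnc(Nc3ccc(F)c(Cl)c3)c2cc1NC(=O)N/N=C/c1cccc(Br)c1` is reported as "not active" (no number reported) and has no number. In this assay, within the data shown here, compound 2 `COc1cc2ncnc(Nc3ccc(F)c(Cl)c3)c2cc1NC(=O)N/N=C/c1ccc(OC)c(OC)c1OC` gives 29300 nM as the only number available, so it cannot yet be ranked against another value. Among the measured compounds shown here, compound 3 `COc1cc2ncnc(Nc3ccc(F)c(Cl)c3)c2cc1NC(=O)N/N=C/c1ccc(O)cc1O` keeps the shared core but carries 2,4-dihydroxyphenyl in place of 2,3,4-trimethoxyphenyl on a carbon with a double bond to nitrogen as its one change. For the measured compounds named here, no measured step guides this swap, so the estimated step of a 1.3-fold lower number from compound 2 to compound 3 (0.12 log units; within the scatter) is expected to stay within the scatter. Compound 3 is estimated at 22000 nM with an expected range from 7000 nM to 70000 nM in this test.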

Compound 3, half-maximal inhibitory concentration: 29500 nM
Compound 3: middle estimate off by 1.3-fold (0.13 log units), on the low side; measured number inside the range.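

Placing 2,4-dihydroxyphenyl in place of 2,3,4-trimethoxyphenyl on a carbon with a double bond to nitrogen gives a 1.0-fold higher number from compound 2 to compound 3 (0.00 log units; within the scatter) in this assay and provides the first comparison of two numbers at this position. The entering group has fewer heavy atoms and adds hydrogen-bond donors, yet the two compounds cannot be told apart on this read-out. No measurement shown here accounts for this result. Still open, on these data alone, is whether an amine or a carboxylic acid on this aromatic ring would change the number.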